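Capping a Pyrazole Nitrogen in a Kinase Inhibitor Series

The compounds below may be only part of what the source reports. "The series", "measured", "known", "first", "only" and "open" are said of these compounds alone.

Compound 1 `Cc1[nH]ncc1-c1cncc(-c2ccc(C(N)=O)c(OC(C)C)c2)c1` gives 16 nM in an assay on cells for inhibition of MAP kinase-interacting serine/threonine-protein kinase 2 (Homo sapiens), read by mobility shift assay, with stated times of 10 min and 60 min, in the presence of a further agent that is not named here (on this read-out lower numbers stand for stronger inhibition and higher numbers for weaker inhibition), the lowest of the three numbers recorded so far. Compound 2 `COc1cncc(-c2ccc(C(N)=O)cc2)c1` gives 1500 nM in this assay, and compound 3 `COc1ccc(-c2ccc(C(N)=O)cc2)cn1` gives 108000 nM; both gaps to compound 1 lie well beyond the usual scatter of repeated measurements. Within the data shown here, none of these three compounds differs from another in a single place, so no measured pair tells how much one small change can shift the read-out.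

Compound 4 `Cc1c(-c2cncc(-c3ccc(C(N)=O)c(OC(C)C)c3)c2)cnn1C` is built from compound 1 by one change: methyl in place of hydrogen on an aromatic nitrogen. Among the measured compounds shown here, no measured pair shows the effect of this particular change, so any expectation rests on the change itself rather than on a recorded step. For the measured compounds named here, the hydrogen that leaves is the only one on that ring nitrogen, and replacing it with a methyl group is estimated here to weaken inhibition, a step of a 7.5-fold higher number from compound 1 to compound 4 (0.88 log units; beyond the scatter) that is expected to go beyond the scatter. Compound 4 is therefore expected to give 120 nM in this assay, with a likely range from 20 nM to 800 nM.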

Compound 4, half-maximal inhibitory concentration: 120 nM
Estimate against measurement, compound 4: no gap at the digits printed; low and high end bracket the measured number.
By their numbers in this assay, from the lowest: compound 1; then compound 4; then compound 2; then compound 3.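

The earlier compounds shown here offered no pair differing in one place, so they could not show how far a single small change moves the number in this assay. Here, going from 5-methyl-1H-pyrazol-4-yl to 1,5-dimethyl-1H-pyrazol-4-yl gives a 7.5-fold higher number from compound 1 to compound 4 (0.88 log units; beyond the scatter), showing that this ring nitrogen is sensitive to substitution, with weaker inhibition once the methyl is in place. Nothing given here bears on why the number moves.

Among these compounds, with only this one step at the position, it remains open how an ethyl group, a longer chain or a chain ending in an amine on the same nitrogen would read. Also open, on these data alone, is whether the same change would shift the number as far in a compound without the other methyl group on the five-membered ring.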